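Notes on halogenated benzyl analogues and an estimate for compound 4

The source may report more compounds than this note shows. Statements on the series, on what has been measured and on what is new or still open speak of the compounds shown alone.

Compound 3 `O=c1c2cnn(-c3ccc(F)cc3)c2ncn1CC1(O)CCN(Cc2cc(F)cc(F)c2)CC1` carries a 3,5-difluorobenzyl group on the shared core. In an assay on Sf21 cells for inhibition of ubiquitin carboxyl-terminal hydrolase 7 (Homo sapiens), read by spectrophotometry, with stated times of 30 min and 2 h (on this read-out lower numbers stand for stronger inhibition and higher numbers for weaker inhibition), compound 3 stands at "not determined" (no result reported), so it cannot be placed against the measured members of the series. Among the measured compounds shown here, compound 1 `O=c1c2cnn(-c3ccc(F)cc3)c2ncn1CC1(O)CCN(Cc2ccc(Br)cc2)CC1` gives 6700 nM in this assay, and compound 2 `COC(=O)c1ccc(CN2CCC(O)(Cn3cnc4c(cnn4-c4ccc(F)cc4)c3=O)CC2)cc1` gives 4500 nM in the same assay; the step of a 1.5-fold lower number from compound 1 to compound 2 (0.17 log units; within the scatter) is the only single-point comparison available. Compound 4 `O=c1c2cnn(-c3ccc(F)cc3)c2ncn1CC1(O)CCN(Cc2ccc(Br)cc2Cl)CC1` differs from compound 3 by 4-bromo-2-chlorophenyl in place of 3,5-difluorophenyl on a saturated chain carbon bound to an amine nitrogen in a ring. For the measured compounds named here, no measured step bears directly on this change; the closest reference is compound 1, which also carries a bromo group on its benzyl substituent, and the step from compound 1 to compound 2 shows that altering that benzyl substituent moved the read-out only a little. A value near that of compound 1 is therefore expected for compound 4, with no direction of change beyond the scatter. Compound 4 is estimated at 5500 nM in this assay, with a range of 2000 nM to 15000 nM.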

Compound 4, half-maximal inhibitory concentration: 1900 nM
Beside the measured number, compound 4's estimate is 2.9-fold (0.46 log units) above it, outside the stated range (below it).
By their numbers in this assay, from the lowest: compound 4; then compounds 2 and 1 (each within the scatter of the next).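

In this assay, among the compounds shown here, chloro in place of hydrogen on an aromatic carbon gives a 3.5-fold lower number from compound 1 to compound 4 (0.55 log units; beyond the scatter), the first step at this benzyl substituent that lies beyond the scatter. Set against the 4-(methoxycarbonyl)phenyl group, 4-bromo-2-chlorophenyl gives a 2.4-fold lower number from compound 2 to compound 4 (0.37 log units; beyond the scatter), which leaves compound 4 with the lowest number of the three compounds that have values, though both steps are modest. Nothing at hand bears on what lies behind these steps.

Going by these compounds, compound 3 has no number, so the steps to it cannot be read, and the standing of 3,5-difluorobenzyl against 4-bromo-2-chlorobenzyl stays unknown. Also open, on these data alone, is how the read-out would respond to a 2-chlorobenzyl group without the bromo, or to a carboxylic acid or an amine on the benzyl ring.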